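The source may report more compounds than this note shows. Statements on the series, on what has been measured and on what is new or still open speak of the compounds shown alone.

In a physicochemical assay for solubility, in phosphate buffer, with a stated time of 18 h (a higher number here means a more soluble compound, a lower number a less soluble compound), compound 1 `CC(C)c1ncc2c(N)c(C#N)c(N)nc2n1` gives > 1000000 nM, which is a limit of the assay and not a number. Compound 2 `CC(C)Cc1ncc2c(N)c(C#N)c(N)nc2n1` gives 268000 nM. Compound 3 `CC(C)(C)c1nc(-c2cccs2)c2c(N)c(C#N)c(N)nc2n1`, which carries a tert-butyl group and a thiophen-2-yl group on the shared core, gives 56000 nM, the lowest number of the three, with compound 2 the nearest to it.

The step to compound 4 `CC(C)(C)c1nc(-c2ncc[nH]2)c2c(N)c(C#N)c(N)nc2n1` puts 1H-imidazol-2-yl in place of thiophen-2-yl on an aromatic carbon, meta to the tert-butyl group: 1H-imidazol-2-yl in place of thiophen-2-yl on an aromatic carbon.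

Going by the values given here, no measured step touches this group. The only one available is an at least 3.7-fold lower number from compound 1 to compound 2 (0.57 log units; beyond the scatter), which has isobutyl in place of isopropyl and lies beyond the scatter. It bears on the present change only as a guide to how far one substitution on this core can move the number in this assay. Among the compounds with values here, with compound 3 at 56000 nM as the lowest number so far, a moderate move to a higher number is expected, although no measurement fixes that direction. The expected change is a 1.6-fold higher number from compound 3 to compound 4 (0.21 log units; within the scatter). For compound 4 the estimated value is 90000 nM, with an expected range of 25000 nM to 350000 nM.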

Compound 4, solubility: < 1000 nM
Compound 4: a limit, no number; the forecaster's own chance of this, stated with the estimate: 5%; middle value at least 90-fold (1.95 log units) from the limit.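

In this assay, the change from thiophen-2-yl to 1H-imidazol-2-yl, on the aromatic carbon next to the ring nitrogen, gives an at least 56-fold lower number from compound 3 to compound 4 (1.74 log units; beyond the scatter), and this is the first step at this position among the compounds shown. Compound 4 gives < 1000 nM, which is a limit of the assay and not a number: the limit of < 1000 nM in this assay, at which 1 of the 4 values shown sits. Both groups have 5 heavy atoms and no net charge, so this large step goes with a change in ring composition, from 4 carbon and 1 sulfur to 3 carbon and 2 nitrogen, and with 1 hydrogen-bond donor entering where the thiophen-2-yl group has none, rather than with a change in heavy-atom count.

Going by these compounds alone, the single pair cannot tell whether the step follows the hydrogen on the ring nitrogen, the second ring nitrogen or the loss of sulfur, and a 1-methylimidazol-2-yl or a thiazol-2-yl group at this position would help to separate these. As far as these compounds go, how far compound 4 lies beyond its limit also stays open, as does whether the same change would behave alike with an isopropyl or isobutyl group in place of the tert-butyl group.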